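This account rests on a few compounds, and the source may have more. Where it says the series, first, only, none or still open, it means among the compounds named here.

Three compounds share one core, a hydrazone linked to a benzothiazole-bearing benzamide, and differ only in the ring hanging from the carbon with a double bond to nitrogen. In an assay on isolated protein for inhibition of Maltase-glucoamylase (Homo sapiens), with a stated time of 15 min (on this read-out lower numbers stand for stronger inhibition and higher numbers for weaker inhibition), compound 1 `O=C(N/N=C\c1ccccn1)c1ccc(-c2nc3ccccc3s2)cc1` gives 10200 nM and compound 2 `O=C(N/N=C/c1ccc(O)cc1)c1ccc(-c2nc3ccccc3s2)cc1` gives 11300 nM. Compound 3 `O=C(N/N=C/c1ccccc1O)c1ccc(-c2nc3ccccc3s2)cc1` gives 5550 nM, the lowest of the three numbers, though the gap to compound 1, a 1.8-fold lower number from compound 1 to compound 3 (0.26 log units; within the scatter), lies within the scatter, so the two cannot be ranked. Against compound 2 the picture is clearer: moving the hydroxyl gives a 2.0-fold lower number from compound 2 to compound 3 (0.31 log units; beyond the scatter), a modest but real change.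

Compound 4 `O=C(N/N=C/c1cccc(O)c1)c1ccc(-c2nc3ccccc3s2)cc1` keeps every atom of compound 3 and moves the hydroxyl once more: 3-hydroxyphenyl in place of 2-hydroxyphenyl on a carbon with a double bond to nitrogen. For the measured compounds named here, the only step that bears on this is the one from compound 2 to compound 3, where shifting the hydroxyl from one ring position to another changed the number by a small, just-detectable amount. A further shift to a third position is therefore expected to stay inside the same narrow band, most likely landing between the numbers of compound 2 and compound 3 with no step beyond the scatter, a 1.4-fold higher number from compound 3 to compound 4 (0.16 log units; within the scatter). The estimate for compound 4 is therefore 8000 nM, with a range from 4000 nM to 16000 nM.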

Compound 4, half-maximal inhibitory concentration: 9210 nM
Beside the measured number, compound 4's estimate is 1.2-fold (0.06 log units) below it, within the range that was stated.
By their numbers in this assay, from the lowest: compounds 3, 4, 1 and 2 (each within the scatter of the next, the first and the last beyond it).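

Compound 4 adds a third hydroxyl placement, and in this assay 3-hydroxyphenyl cannot be separated from either 2-hydroxyphenyl (a 1.7-fold higher number from compound 3 to compound 4 (0.22 log units; within the scatter)) or 4-hydroxyphenyl (a 1.2-fold lower number from compound 2 to compound 4 (0.09 log units; within the scatter)), so the gap between compound 2 and compound 3 remains the only one in this set beyond the scatter, and it stays modest. The ring of compound 1, which has no hydroxyl and carries one hetero atom, cannot be told apart from 3-hydroxyphenyl either (a 1.1-fold lower number from compound 1 to compound 4 (0.04 log units; within the scatter)), so at this position the hydroxyl shows no clear gain or loss unless it is compared across the 2-hydroxyphenyl and 4-hydroxyphenyl pair. No supporting measurement is available to explain these numbers.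

The compounds shown leave open whether a different group on this ring, such as a methoxy, an amine or a carboxylic acid, would shift the number by more than moving the hydroxyl does. They also leave open whether a second hydroxyl on the same ring would widen the modest gap seen so far, or whether changes elsewhere on the shared core matter more than this position.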